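Amino for Azido at the Cytotoxicity Limit

The source may report more compounds than this note shows. Statements on the series, on what has been measured and on what is new or still open speak of the compounds shown alone.

compound 1 `Cc1cc(C)cc(Cn2c(=O)cc(N=[N+]=[N-])n(Cc3ccccn3)c2=O)c1`: > 100000 nM
compound 2 `Cc1cc(C)cc(Cn2c(=O)cc(NCc3ccccc3)n(Cc3ccccc3)c2=O)c1`: > 100000 nM
compound 3 `Cc1cc(C)cc(Cn2c(=O)cc(N3CCCCC3)n(Cc3ccccc3)c2=O)c1`: 47000 nM

In an ADME assay on MT4 cells (Homo sapiens) for cytotoxicity, read by MTT assay, with a stated time of 4 days (on this read-out higher numbers stand for lower toxicity in this test and lower numbers for higher toxicity in this test), compound 1 reached only the limit of the assay, > 100000 nM, so no number is known for it. Compound 2 likewise stopped at the limit of > 100000 nM. Compound 3 gave 47000 nM, and an at least 2.1-fold lower number from compound 2 to compound 3 (0.32 log units; beyond the scatter). Two of the three values sit at the limit of > 100000 nM in this assay, at which 2 of the 3 values shown sit, which leaves the scale largely unresolved. Compound 4 `Cc1cc(C)cc(Cn2c(=O)cc(N)n(Cc3ccccn3)c2=O)c1` differs from compound 1 by amino in place of azido on an aromatic carbon. Within the data shown here, no measured step exchanges azido for amino, and the step from compound 2 to compound 3 concerns another group, so it does not bear on this change. Compound 1 stands at the limit > 100000 nM. Given that, compound 4 is expected near 100000 nM, between 40000 nM and 250000 nM, with a number no higher from compound 1 to compound 4 (the limit leaves the size open) meaning no change beyond the scatter and a good chance of again only a limit.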

Compound 4, half-maximal cytotoxic concentration: > 100000 nM
Compound 4 ended at the assay's limit; the forecaster's own chance of this, stated with the estimate: 70%; the middle value sits exactly at the limit.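

Compound 1 and compound 4 both stopped at a limit of this assay, not at a number, and the step between them cannot be read. The compounds shown leave open whether amino in place of azido changes the read-out at all.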